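The source may hold more compounds than are shown below. What is called first, only, known or untested is meant among the compounds shown, and "the series" means these compounds.

Measured compounds:

Compound 1 `COc1ccc(/C=N/NC(=S)NC(C)(C)[C@H]2CC=C(C)CC2)cc1` — 33600 nM
Compound 2 `COc1cc(/C=N/NC(=S)NC(C)(C)[C@H]2CC=C(C)CC2)ccc1O` — < 700 nM

In a functional assay on HT-29 cells (Homo sapiens) for inhibition, read by sulforhodamine B assay, with a stated time of 48 h (a lower number here means a stronger inhibitor of growth, a higher number a weaker inhibitor of growth), compound 1 gives 33600 nM. Going by the values given here, this is the only full number so far. Compound 2 is reported in this assay only as a limit, < 700 nM, so the pair of compounds 1 and 2 cannot be turned into a sized step; what the two values show is that compound 2 sits at the limit of < 700 nM in this assay, at which 1 of the 2 values shown sits, while compound 1 sits well away from it.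

Compound 3 `CC1=CC[C@H](C(C)(C)NC(=S)N/N=C/c2ccc[nH]2)CC1` is not yet measured. It differs from compound 1 in one place: 1H-pyrrol-2-yl in place of 4-methoxyphenyl on a carbon with a double bond to nitrogen. The shared core, the thiosemicarbazide chain bearing the substituted cyclohexenyl group, is kept.

Among the compounds with values here, no measured step matches this change, and compound 2 gives only a limit, so the expectation rests on compound 1 alone. Compound 3 is expected to stay close to compound 1, with the step from compound 1 to compound 3 estimated as a 1.7-fold lower number from compound 1 to compound 3 (0.23 log units; within the scatter), with the possibility of a weaker or stronger outcome either way. The estimate for compound 3 in this assay is 20000 nM, within a range of 4000 nM to 80000 nM.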

Compound 3, concentration for total growth inhibition: > 100000 nM
Compound 3: no number, only a limit; the forecaster's own chance of this, stated with the estimate: 10%; at least 5.0-fold (0.69 log units) between middle value and limit.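

Going by these compounds alone, replacing 4-methoxyphenyl with 1H-pyrrol-2-yl on a carbon with a double bond to nitrogen gives the first readable step at this position in this assay: an at least 2.9-fold higher number from compound 1 to compound 3 (0.47 log units; beyond the scatter), so growth inhibition is sensitive to the group held here. Compound 3 is reported only as a limit, not as a number, so the step has a lower bound and no full size: the limit of > 100000 nM in this assay, at which 1 of the 3 values shown sits. The change replaces a six-membered aromatic ring of carbon only with a five-membered aromatic ring with 1 hetero atom, and it also brings in 1 hydrogen-bond donor and removes 1 hydrogen-bond acceptor, so this single pair cannot separate these differences.

Steps involving compound 2 cannot be read, and the compounds shown leave open whether ring size, the ring nitrogen with its hydrogen, or the absence of the methoxy group accounts for the step. A plain phenyl group and a furan-2-yl group, with oxygen as the ring hetero atom, at the same place would help to separate these possibilities.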